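Compound 2 gains an amino group

The source may report more compounds than this note shows. Statements on the series, on what has been measured and on what is new or still open speak of the compounds shown alone.

Measured so far in a physicochemical assay for metabolic stability, read by HPLC, at pH 4.5, tested at 10 uM (a lower number here means that the compound disappears faster, a higher number that the compound lasts longer), and read as half-lives:
Compound 1 `COc1nc2ccccc2n1C(=O)NCCCCc1ccccc1` gives > 2 h
Compound 2 `O=C(NCCCCc1ccccc1)n1cnc2ccccc21` gives > 2 h
Compound 3 `CCCCCCNC(=O)n1cnc2ccccc21` gives > 2 h

In this assay compound 2 gives > 2 h as a limit of the assay and not as a number. It shares this position with its two neighbours, and the whole set rests on one finding (  the limit of > 2 h in this assay, at which 3 of the 3 values shown sit). Compound 4 `Nc1nc2ccccc2n1C(=O)NCCCCc1ccccc1` differs from compound 2 by one change on the shared core amino in place of hydrogen on an aromatic carbon and in words this is amino in place of hydrogen on an aromatic carbon.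

Two measured steps can be consulted. The nearer one is a swap at this same aromatic carbon, with hydrogen in place of methoxy (a step that the two limits leave unreadable from compound 1 to compound 2). The other lies far along the chain, with ethyl in place of phenyl (a step that the two limits leave unreadable from compound 2 to compound 3). Neither gives a size to carry over, so they offer no direction either. Compound 1 carries a group on this carbon and gives > 2 h as a limit of the assay. A step no larger than the scatter is therefore expected, and the estimate is a step that the limit leaves unreadable from compound 2 to compound 4 with no firm direction. For compound 4 the estimated half-life in this assay is 3 h within an expected range of 1 h to 8 h and a limit in place of a number would be no surprise.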

Compound 4, half-life: 0.717 h
The estimate for compound 4 lay 4.2-fold (0.62 log units) above the measured number, and the stated range ends above it.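

In this assay, for the compounds shown here, compound 4 gives the first real number in the set, 0.717 h, so this aromatic carbon, between two ring nitrogen atoms, is a place where a single change can be read. Amino in place of hydrogen gives an at least 2.7-fold lower number from compound 2 to compound 4 (0.44 log units; beyond the scatter), and amino in place of methoxy on the same carbon gives an at least 2.7-fold lower number from compound 1 to compound 4 (0.44 log units; beyond the scatter), so carrying a group here is not enough on its own to make a compound disappear faster: the outcome depends on which group it is. The earlier steps shown here among the first three compounds cannot be read, and both new steps give only a smallest size, because their starting compounds rest on the assay limit: the limit of > 2 h in this assay, at which 3 of the 4 values shown sit.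

The compounds shown leave open whether this drop belongs to amino alone or would also appear with a hydroxyl or a methylamino group on this carbon. They also leave open whether amino here would give a similar step on the shorter-looking chain of compound 3, where only hexyl-type chains without the phenyl are represented.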